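Methyl for Fluoro on the Aromatic Ring of Compound 1

The compounds below may be only part of what the source reports. "The series", "measured", "known", "first", "only" and "open" are said of these compounds alone.

Measured compounds:
compound 1, `CSc1ccc(F)cc1NCC1=NCCN1`, 90%
compound 2, `CS(=O)(=O)c1cc(F)ccc1NCC1=NCCN1`, 61%

In a functional assay for agonist activity at Alpha-1A adrenergic receptor (Homo sapiens) (a higher number here means a larger maximal response, a lower number a smaller maximal response), compound 1 gives 90%, the highest of the two numbers; compound 2 gives 61%, a gap beyond the scatter. Compound 3, `CSc1ccc(C)cc1NCC1=NCCN1`, has not been measured. It differs from compound 1 as follows: methyl in place of fluoro on an aromatic carbon. Among the compounds with values here, no measured pair shows this change, so its size is unknown; a step from compound 1 to compound 3 no larger than the scatter, in either direction, is expected, a number 5 percentage points lower from compound 1 to compound 3 (within the scatter). Compound 3 is estimated at 85%, between 65% and 100%.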

Compound 3, largest response reached (reported as maximum), in percent of the reference or control that the assay uses: 101%
Compound 3: middle estimate off by 16 percentage points, on the low side; measured number outside the range, above it.
By their numbers in this assay, from the lowest: compound 2; then compound 1; then compound 3.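

In this assay, the exchange of fluoro for methyl at this aromatic carbon, para to a methylsulfanyl group, gives a number 11 percentage points higher from compound 1 to compound 3 (beyond the scatter). This place on the ring is therefore not silent: one heavy atom exchanged, with no change in the hydrogen-bond donors or acceptors counted, is enough to shift the maximal response. No measurement available bears on the reason for this rise. On these data alone, it remains open whether a methoxy group, an ethyl chain or an amine at this place would raise the response further or lower it. As far as these compounds go, whether methyl gives a similar step alongside the methylsulfonyl group of compound 2 also remains open.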